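This account rests on a few compounds, and the source may have more. Where it says the series, first, only, none or still open, it means among the compounds named here.

The study concerns agonists measured in a functional assay for agonist activity at G protein-coupled receptor 88 (Homo sapiens), read by HTRF and cAMP accumulation; a lower number here means that less compound is needed, a higher number that more compound is needed for the effect. Compound 1, `CO[C@H](C)[C@H](N)CN(C(=O)[C@@H]1C[C@H]1c1ccccc1)c1ccc(-c2ccccc2)cc1`, gives 0.68 nM in this assay. Compound 2, `O=C([C@@H]1C[C@H]1c1ccccc1)N(CCNCC1CCCC1)c1ccc(-c2ccccc2)cc1`, gives 2.5 nM. Among the compounds with values here, the only pairwise comparison among the measured compounds that rests on a single change is a 3.7-fold higher number from compound 1 to compound 2 (0.57 log units; beyond the scatter). Compound 3, `CC[C@H](C)[C@H](N)CN(C(=O)[C@@H]1C[C@H]1c1cccc(Cl)c1)c1ccc(-c2ccccc2)cc1`, gives 2200 nM, the highest of the three numbers; it stands far beyond the scatter from compound 2 and further still from compound 1, but it differs from each of them in more than one place, so no single change can be read from either gap.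

Compound 4, `CC[C@H](C)[C@H](N)CN(C(=O)[C@@H]1C[C@H]1c1cc(F)cc(F)c1)c1ccc(-c2ccccc2)cc1`, has not yet been measured. It differs from compound 3 in one place: 3,5-difluorophenyl in place of 3-chlorophenyl on a saturated ring carbon. Within the data shown here, none of the measured steps touches this part of the molecule; the one known step concerns the chain on the amide-type nitrogen, not the group on the saturated ring carbon. The account therefore has only the number for compound 3 to lean on. The expected step is a 1.5-fold lower number from compound 3 to compound 4 (0.17 log units; within the scatter), which would stay within the scatter. Compound 4 is accordingly expected to give about 1500 nM in this assay, estimated to fall between 300 nM and 8000 nM.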

Compound 4, half-maximal effective concentration: 960 nM
The estimate for compound 4 lay 1.6-fold (0.19 log units) above the measured number; the measured number falls inside the stated range.
By their numbers in this assay, from the lowest: compound 1; then compound 2; then compound 4; then compound 3.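

Within the data shown here, compound 3 and compound 4 give the first reading at the aryl group on the saturated ring carbon of the three-membered ring. In this assay, 3,5-difluorophenyl in place of 3-chlorophenyl gives a 2.3-fold lower number from compound 3 to compound 4 (0.36 log units; beyond the scatter), so this position responds measurably to a change in the group it carries, which the earlier step, confined to the chain on the amide-type nitrogen, could not show. The step is modest, however, and no supporting data here explain it.

This single exchange removes chlorine and brings in two fluorines together, so it cannot say which part of the change carries the step, and a phenyl ring bearing a single fluorine, a methoxy group or a nitrile, or a pyridine ring in its place, would be needed to take the reading further. From the compounds shown here alone, it also remains open whether the same exchange would give a step of similar size alongside the 1-amino-2-methoxypropyl chain of compound 1 or the ((cyclopentylmethyl)amino)methyl chain of compound 2.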